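Trifluoromethyl in place of trifluoromethoxy: expected inhibition

The source may report more compounds than this note shows. Statements on the series, on what has been measured and on what is new or still open speak of the compounds shown alone.

Two measured compounds share one core and differ at a single aromatic carbon. Compound 1 `CCc1ccc2nc(C(=O)Nc3c(F)cc(-c4cccc(F)c4)cc3F)c(C)c(O)c2c1` carries an ethyl there, and in a functional assay on Hep 3B2 cells (Homo sapiens) for antiproliferative activity, read by MTT assay, with a stated time of 24 h, tested at 1.23 ug/mL (a lower number here means a weaker effect, a higher number a stronger effect of the compound at the concentration tested), compound 1 gives 23.5%. Compound 2 `Cc1c(C(=O)Nc2c(F)cc(-c3cccc(F)c3)cc2F)nc2ccc(OC(F)(F)F)cc2c1O` carries trifluoromethoxy at that carbon; in this assay compound 2 gives 17.2%, the lower of the two numbers, though the step of a number 6.3 percentage points lower from compound 1 to compound 2 (within the scatter) lies within the scatter, so the two values cannot be ranked. Compound 3 `Cc1c(C(=O)Nc2c(F)cc(-c3cccc(F)c3)cc2F)nc2ccc(C(F)(F)F)cc2c1O` is the unmeasured member, differing from compound 2 by trifluoromethyl in place of trifluoromethoxy on an aromatic carbon. Among the measured compounds shown here, the only measured step at this carbon, a number 6.3 percentage points lower from compound 1 to compound 2 (within the scatter), stayed within the scatter, and no measured step exchanges trifluoromethoxy for trifluoromethyl, so the step of a number 1.8 percentage points higher from compound 2 to compound 3 (within the scatter) in this assay is expected to stay within the scatter, with no direction. Compound 3 is therefore estimated at 19%, in a range from 7% to 32%.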

Compound 3, a percentage reported as inhibition, at one concentration (the size of the read-out at that concentration, not a potency): 15.3%
Compound 3: the middle estimate sits 3.7 percentage points above what was measured; low and high end bracket the measured number.
By their numbers in this assay, from the lowest: compounds 3, 2 and 1 (each within the scatter of the next).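

In this assay, the exchange of trifluoromethoxy for trifluoromethyl gives a number 1.9 percentage points lower from compound 2 to compound 3 (within the scatter), and the exchange of ethyl for trifluoromethyl gives a number 8.2 percentage points lower from compound 1 to compound 3 (within the scatter). Every pair among the three groups at this aromatic carbon now has a step within the scatter, so ethyl, trifluoromethoxy and trifluoromethyl cannot be ranked here, and the loss of the oxygen shows no readable effect on the number. Nothing available bears on why these substituents read alike.

From the compounds shown here alone, whether an amine, a carboxylic acid or a longer chain on this aromatic carbon would give a step beyond the scatter stays open. Also open, going by these compounds, is whether compound 1, compound 2 and compound 3 would separate in the size of their effect at another concentration; the read-out here covers a single concentration only.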